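Sulfonamide aryl substituent: methoxy exchanged for cyano

The source may report more compounds than this note shows. Statements on the series, on what has been measured and on what is new or still open speak of the compounds shown alone.

Compound 3 `COc1ccc(NS(=O)(=O)c2ccc3c(c2)C(n2ccccc2=O)=CC(C)(C)O3)cc1` reaches 84.2% in a functional assay on the whole organism (trachea) with Rattus norvegicus as the target (a lower number here means a smaller maximal response, a higher number a larger maximal response), the second highest of the three measured numbers. Compound 1 `CNS(=O)(=O)c1ccc2c(c1)C(n1ccccc1=O)=CC(C)(C)O2` reaches 83% and compound 2 `CC(C)NS(=O)(=O)c1ccc2c(c1)C(n1ccccc1=O)=CC(C)(C)O2` reaches 94.8%. The nearest neighbour of compound 3 is separated by a number 1.2 percentage points higher from compound 1 to compound 3 (within the scatter); the furthest by a number 10.6 percentage points lower from compound 2 to compound 3 (beyond the scatter). The remaining measured step, a number 11.8 percentage points higher from compound 1 to compound 2 (beyond the scatter), also concerns the group on the sulfonamide nitrogen.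

Compound 4 `CC1(C)C=C(n2ccccc2=O)c2cc(S(=O)(=O)Nc3ccc(C#N)cc3)ccc2O1` is not yet measured. It differs from compound 3 by cyano in place of methoxy on an aromatic carbon. Among the compounds with values here, all three measured steps exchange the group on the sulfonamide nitrogen; none exchanges a substituent on the phenyl ring, so no step bears directly on this change. The largest measured step is modest and the smallest lies within the scatter, and the series as a whole spans only a narrow band of maximal response. For compound 4 a step of a number 0.2 percentage points lower from compound 3 to compound 4 (within the scatter) is therefore expected, none beyond the scatter. Compound 4 is estimated at 84%, with a range from 74% to 94%.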

Compound 4, largest response reached (Emax), in percent of the reference or control that the assay uses: 90.8%
Compound 4: middle estimate off by 6.8 percentage points, on the low side, and the stated range covers the measured number.
By their numbers in this assay, from the lowest: compounds 1, 3, 4 and 2 (each within the scatter of the next, the first and the last beyond it).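

Cyano in place of methoxy, on the aromatic carbon para to a large group, is the first exchange on the phenyl ring itself and gives a number 6.6 percentage points higher from compound 3 to compound 4 (within the scatter) in this assay as its measured step. With 4-cyanophenyl on the sulfonamide nitrogen, the series shows a number 4 percentage points lower from compound 2 to compound 4 (within the scatter) and a number 7.8 percentage points higher from compound 1 to compound 4 (within the scatter) so this group stays within the scatter of both isopropyl and methyl, whereas 4-methoxyphenyl and isopropyl are separated by a number 10.6 percentage points lower from compound 2 to compound 3 (beyond the scatter) as a step beyond it. Nothing measured on these groups accounts for these steps.

Going by these compounds, whether the phenyl ring tolerates an amine or a carboxylic acid at this place with as small a step remains open. On these data alone, the effect of a longer chain on the sulfonamide nitrogen also remains open.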